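The compounds below may be only part of what the source reports. "The series", "measured", "known", "first", "only" and "open" are said of these compounds alone.

Measured so far, in a physicochemical assay for lipophilicity, measured as octanol-water partition; a higher number here means a more lipophilic compound, a lower number a more polar compound:
Compound 1 `CC1=C(C(=O)OCc2cccnc2)C(c2ccco2)C2=C(CCCC2=O)N1` gives 1.03.
Compound 2 `CC1=C(C(=O)OCc2ccccn2)C(c2ccco2)C2=C(CCCC2=O)N1` gives 1.4.
Compound 3 `CC1=C(C(=O)OCc2cccnc2)C(c2ccc(Cl)cc2)C2=C(CCCC2=O)N1` gives 1.87.

Compound 4 `CC1=C(C(=O)OCc2ccccn2)C(c2ccc(Cl)cc2)C2=C(CCCC2=O)N1` has not yet been measured in this assay. It differs from compound 3 by one change: pyridin-2-yl in place of pyridin-3-yl on a saturated chain carbon bound to an oxygen next to a carbonyl group. The same change, at the same place, has already been measured once, from compound 1 to compound 2: pyridin-2-yl in place of pyridin-3-yl on a saturated chain carbon bound to an oxygen next to a carbonyl group, and there it made a step of a number 0.37 log units higher from compound 1 to compound 2 (beyond the scatter). The two pairs sit on cores that differ from one another in one place: 4-chlorophenyl in place of furan-2-yl on a saturated ring carbon, which made a step of a number 0.84 log units higher from compound 1 to compound 3 (beyond the scatter). Compound 3 stands highest of the three measured numbers in this assay, with compound 2 nearest and compound 1 furthest.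

Within the data shown here, for compound 4 the step from compound 3 is expected to be about a number 0.37 log units higher from compound 3 to compound 4 (beyond the scatter), close to the earlier step of a number 0.37 log units higher from compound 1 to compound 2 (beyond the scatter), since that is the only measurement of this change and nothing among the measured compounds shows the change behaving differently on the core of compound 3. Compound 4 is therefore estimated at 2.24 in this assay, with a likely range from 1.9 to 2.6.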

Compound 4, partition coefficient: 2.24
For compound 4 middle estimate and measured number coincide at the digits printed; measured number inside the range.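

In this assay, pyridin-2-yl in place of pyridin-3-yl makes a step of a number 0.37 log units higher from compound 3 to compound 4 (beyond the scatter) on the core carrying 4-chlorophenyl, the same size as the step of a number 0.37 log units higher from compound 1 to compound 2 (beyond the scatter) on the core carrying furan-2-yl; read the other way, 4-chlorophenyl in place of furan-2-yl makes a step of a number 0.84 log units higher from compound 2 to compound 4 (beyond the scatter) and so matches the earlier step of a number 0.84 log units higher from compound 1 to compound 3 (beyond the scatter) in size. The two changes therefore simply add up across these four compounds, but this is a single pair of cores, so it shows that the step carried over here and does not show that it would carry over to every core in the series. No measurement at hand says what lies behind the size of either step.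

The compounds shown hold only two groups at each of the two places. From the compounds shown here alone, it remains open whether the step from pyridin-3-yl to pyridin-2-yl would stay the same with an amine or a carboxylic acid on the saturated ring carbon, and how a plain phenyl or a pyridin-4-yl would fit on the saturated chain carbon.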